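A few compounds are considered here, and "the series" means these few. Any claim that something is new, unique, unknown or untested is made for them only; others in the source may bear on it.

Working notes on the series. Compound 1 `CCCCCCCCCCc1ccc(-c2noc(C3CCNCC3)n2)cc1` in an assay on HeLa cells for inhibition of sphingosine-1-phosphate transporter SPNS2 (Mus musculus), read by LC-MS, tested at 2 uM (a lower number here means less inhibition, a higher number more inhibition at the concentration tested (going by the name of the read-out)), gives 66% and stands highest of the three numbers in hand. Compound 2 `CCCCCCCCCCc1ccc(-c2noc(-c3cccc(CN)c3)n2)cc1` in this assay gives 2% and compound 3 `CCCCCCCCCCc1ccc(-c2noc(CC(CN)OC(C)=O)n2)cc1` in this assay gives 0%. Both departures from the piperidin-4-yl of compound 1 cost heavily: a number 64 percentage points lower from compound 1 to compound 2 (beyond the scatter) and a number 66 percentage points lower from compound 1 to compound 3 (beyond the scatter). Compound 4 `CCCCCCCCCCc1ccc(-c2noc(CC(O)CN3CCCCC3)n2)cc1` carries 2-hydroxy-3-(piperidin-1-yl)propyl in place of piperidin-4-yl on an aromatic carbon; the ring of compound 1 is kept but moved out onto a chain, which resembles the step to compound 3 more than that to compound 2. A sizeable fall is therefore expected in this assay, though not necessarily the whole way down. For compound 4 the expected value is 25%, range 0% to 60%, a step of a number 41 percentage points lower from compound 1 to compound 4 (beyond the scatter).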

Compound 4, a percentage reported as inhibition, at one concentration (the size of the read-out at that concentration, not a potency): 2%
Compound 4: middle estimate off by 23 percentage points, on the high side; low and high end bracket the measured number.
By their numbers in this assay, from the lowest: compounds 3, 2 and 4 (each within the scatter of the next); then compound 1.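

Keeping the six-membered non-aromatic ring with 1 hetero atom does not keep the number in this assay: as 2-hydroxy-3-(piperidin-1-yl)propyl, it gives a number 64 percentage points lower from compound 1 to compound 4 (beyond the scatter). Compound 4 cannot be separated from the acyclic group of compound 3, with a number 2 percentage points higher from compound 3 to compound 4 (within the scatter), or from the aromatic group of compound 2, with no change at the digits printed from compound 2 to compound 4 (within the scatter). Among these four compounds, the presence of that ring alone therefore does not set compound 1 apart. On these data alone, whether 1-methylpiperidin-4-yl or pyrrolidin-3-yl at this position would retain the number of compound 1 remains open. Nothing in hand gives a cause for the fall.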